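The compounds below may be only part of what the source reports. "The series", "measured", "known", "first", "only" and "open" are said of these compounds alone.

Measured so far:
compound 1 `O=C(O)c1ccc2noc(-c3ccc(Cc4ccccc4)cc3)c2c1` gives 65 nM in an assay for inhibition of inositol hexakisphosphate kinase 2 (Homo sapiens), read by colorimetric assay, coupled enzyme assay and malachite green, with a stated time of 120 min, in the presence of a further agent that is not named here; on this read-out lower numbers stand for stronger inhibition and higher numbers for weaker inhibition;
compound 2 `O=C(O)c1ccc2noc(-c3ccc(Oc4ccccn4)cc3)c2c1` gives 1190 nM in this assay.

Compound 2 carries the highest number of the two; its nearest neighbour is compound 1, and the step of an 18-fold higher number from compound 1 to compound 2 (1.26 log units; beyond the scatter) is large. Compound 3 `O=C(O)c1ccc2noc(-c3ccc(N4CCCC4=O)cc3)c2c1` is not yet measured. It differs from compound 2 in one place: 2-oxopyrrolidin-1-yl in place of (pyridin-2-yl)oxy on an aromatic carbon, on the aromatic carbon para to a large group. For the measured compounds named here, the only measured step that touches this position is an 18-fold higher number from compound 1 to compound 2 (1.26 log units; beyond the scatter), which shows that the group at this carbon can move the number far. Going by the values given here, the 2-oxopyrrolidin-1-yl ring has no counterpart among the measured compounds, so its direction is open. Compound 3 is therefore expected to shift by a 1.5-fold lower number from compound 2 to compound 3 (0.17 log units; within the scatter), with wide uncertainty. The estimate for compound 3 is 800 nM, within a range from 150 nM to 4000 nM.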

Compound 3, half-maximal inhibitory concentration: 480 nM
The estimate for compound 3 lay 1.7-fold (0.22 log units) above the measured number; low and high end bracket the measured number.
By their numbers in this assay, from the lowest: compound 1; then compound 3; then compound 2.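

In this assay, the aromatic carbon para to a large group now has three groups to compare, and 2-oxopyrrolidin-1-yl gives a 2.5-fold lower number from compound 2 to compound 3 (0.39 log units; beyond the scatter). A five-membered non-aromatic ring at this carbon therefore gives a lower number than the aromatic (pyridin-2-yl)oxy group, yet it does not match benzyl, as the step of a 7.4-fold higher number from compound 1 to compound 3 (0.87 log units; beyond the scatter) shows. Among these three compounds, then, the number depends strongly on the group at this carbon, but no evidence is available to explain the order of the three groups.

The compounds shown leave open whether a phenoxy group would separate the effect of the ring nitrogen from that of the oxygen link in compound 2. They also leave open whether an open-chain amide or a six-membered lactam would bring the number closer to that of compound 1.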